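The source may report more compounds than this note shows. Statements on the series, on what has been measured and on what is new or still open speak of the compounds shown alone.

Compound 1 `COc1cccc(/C=C/c2cc3c(c(=O)n(C)c(=O)n3C)n2C)c1`: 1240 nM. Compound 2 `Cn1c(=O)c2c(cc(/C=C/c3ccc(C(F)(F)F)cc3)n2C)n(C)c1=O`: > 10000 nM, a limit of the assay.

In an assay on isolated protein for inhibition of Amine oxidase [flavin-containing] A (Homo sapiens), read by luminescence, with a stated time of 1 h (a lower number here means a stronger inhibitor, a higher number a weaker inhibitor), compound 1 gives 1240 nM. Compound 2 stands at the limit of > 10000 nM in this assay, at which 1 of the 2 values shown sits, which is a limit of the assay and not a number. Compound 3 `Cn1c(=O)c2c(cc(/C=C/c3ccc(C#N)cc3)n2C)n(C)c1=O` differs from compound 2 by cyano in place of trifluoromethyl on an aromatic carbon. No step between measured compounds is shown, so for this change no movement beyond the usual scatter is expected, in either direction. Compound 3 is therefore estimated at 9000 nM, within 2500 nM to 30000 nM, an expected step of an at least 1.1-fold lower number from compound 2 to compound 3 (0.04 log units; that floor lies within the scatter).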

Compound 3, half-maximal inhibitory concentration: > 10000 nM
Compound 3: no number, only a limit; the forecaster's own chance of this, stated with the estimate: 45%; at least 1.1-fold (0.04 log units) between middle value and limit.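

In this assay, compound 3 gives only a limit of the assay, so the step from trifluoromethyl to cyano cannot be read: the limit of > 10000 nM in this assay, at which 2 of the 3 values shown sit. Cyano in place of trifluoromethyl therefore brings no readable number back. The exchange of 3-methoxyphenyl for 4-cyanophenyl gives an at least 8.0-fold higher number from compound 1 to compound 3 (0.90 log units; beyond the scatter), so this second group on the aromatic ring also falls short of the reading of compound 1.

As far as these compounds go, the true values of compound 2 and compound 3 remain unknown. Also open, from the compounds shown here alone, is whether a 4-methoxyphenyl, a 3-cyanophenyl or an amine on that ring would separate the effect of the group from that of its place.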